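A few compounds are considered here, and "the series" means these few. Any claim that something is new, unique, unknown or untested is made for them only; others in the source may bear on it.

Compound 3 `Cc1ccc(/C=C(/SCc2ccc(F)cc2)C(=O)c2ccc(Cl)cc2)s1` is one of three related compounds tested in a functional assay on DU-145 cells (Homo sapiens) for inhibition, read by trypan blue exclusion, with a stated time of 96 h; a higher number here means a weaker inhibitor of growth, a lower number a stronger inhibitor of growth. Compound 1 `Cc1ccsc1/C=C(/SCc1ccc(Cl)cc1Cl)C(=O)c1ccc(Cl)cc1` gives 10000 nM in this assay. Compound 2 `COc1ccc(S/C(=C/c2ccc(C)s2)C(=O)c2ccc(Cl)cc2)cc1` gives 50000 nM in this assay. Within the data shown here, compound 3, in this assay, reaches only the limit > 100000 nM, so no number is known for it, and it is the one value that sits at the limit of > 100000 nM in this assay, at which 1 of the 3 values shown sits. Among the measured compounds shown here, the single step among the measured compounds, an at least 2.0-fold higher number from compound 2 to compound 3 (0.30 log units; that floor lies within the scatter), runs from a number to that limit and is itself only a floor.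

Compound 4 `Cc1ccc(/C=C(/SCc2ccc(Cl)cc2Cl)C(=O)c2ccc(Cl)cc2)s1` differs from compound 3 in one place: 2,4-dichlorophenyl in place of 4-fluorophenyl on a saturated chain carbon bound to a sulfur. No measured step on the shared core replaces 4-fluorobenzyl with 2,4-dichlorobenzyl, so the direction of the change is not fixed by the steps shown. What the numbers do show is that compound 1, which also carries 2,4-dichlorobenzyl on the sulfur, gives a value well below the limit reached by compound 3. On that basis compound 4 is expected to fall below the limit, by an estimated step of an at least 5.0-fold lower number from compound 3 to compound 4 (0.69 log units; beyond the scatter). The estimate for compound 4 in this assay is 20000 nM, within a range from 5000 nM to 100000 nM.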

Compound 4, concentration for 50% growth inhibition: 50000 nM
The estimate for compound 4 lay 2.5-fold (0.40 log units) below the measured number, and the stated range covers the measured number.
By their numbers in this assay, from the lowest: compound 1; then compounds 2 and 4 (each within the scatter of the next). At a limit, above all of these: compound 3.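

In this assay the change from 4-fluorobenzyl to 2,4-dichlorobenzyl gives an at least 2.0-fold lower number from compound 3 to compound 4 (0.30 log units; that floor lies within the scatter) and so shows no change beyond the scatter at this position. Replacing 4-methoxyphenyl on a sulfur with 2,4-dichlorobenzyl gives no change at the digits printed from compound 2 to compound 4 (within the scatter) and does not separate these two groups. With 2,4-dichlorobenzyl held on the sulfur, 5-methylthiophen-2-yl in place of 3-methylthiophen-2-yl gives a 5.0-fold higher number from compound 1 to compound 4 (0.70 log units; beyond the scatter) and shows that the low number of compound 1 does not carry over with the 2,4-dichlorobenzyl group alone.

On these data alone, compound 3 remains a limit and not a number, so the true size of its step stays open: the limit of > 100000 nM in this assay, at which 1 of the 4 values shown sits. Also open, as far as these compounds go, is how an amine or a carboxylic acid in place of the chlorines, or a longer chain on the sulfur, would read.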